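From 3-chlorophenyl to 3-iodophenyl: working notes

This account rests on a few compounds, and the source may have more. Where it says the series, first, only, none or still open, it means among the compounds named here.

Measured in a functional assay on HeLa cells (Homo sapiens) for antiproliferative activity, read by sulforhodamine B assay, with a stated time of 48 h; on this read-out lower numbers stand for stronger inhibition of growth and higher numbers for weaker inhibition of growth:
compound 1 `Cc1cc2c(cc1C)C(Cl)=C(c1nnc(-c3ccc(F)cc3)o1)CCC2`: 6420 nM
compound 2 `Cc1cc2c(cc1C)C(Cl)=C(c1nnc(-c3cccc(Cl)c3)o1)CCC2`: 5940 nM

Among the compounds with values here, only two numbers are available so far, and compound 2 stands level with compound 1, since the gap between them lies within the scatter. The next compound is compound 3 `Cc1cc2c(cc1C)C(Cl)=C(c1nnc(-c3cccc(I)c3)o1)CCC2`, with iodo in place of chloro on an aromatic carbon, meta to a large group: iodo in place of chloro on an aromatic carbon. The shared core stays the same.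

Within the data shown here, only one measured step bears on this change, and only indirectly: a 1.1-fold lower number from compound 1 to compound 2 (0.03 log units; within the scatter). That step replaced 4-fluorophenyl with 3-chlorophenyl and stayed within the scatter. Among the measured compounds shown here, no pair differing by chloro and iodo at the same place has been measured, so the evidence is thin. On this basis, no step beyond the scatter is expected in this assay, and neither direction is favoured. The estimated step is a 1.1-fold lower number from compound 2 to compound 3 (0.03 log units; within the scatter). For compound 3 the expected value is 5500 nM, with an estimated range from 2600 nM to 11500 nM.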

Compound 3, concentration for 50% growth inhibition: 4460 nM
Compound 3: the middle estimate sits 1.2-fold (0.09 log units) above what was measured, within the range that was stated.
By their numbers in this assay, from the lowest: compounds 3, 2 and 1 (each within the scatter of the next).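

In this assay, within the data shown here, the only pair that differs solely by chloro and iodo at this place gives a 1.3-fold lower number from compound 2 to compound 3 (0.12 log units; within the scatter) and so offers the first direct reading of this exchange: on an aromatic carbon, meta to a large group, the two halogens are not separated. The wider exchange, with 3-iodophenyl in place of 4-fluorophenyl, gives a 1.4-fold lower number from compound 1 to compound 3 (0.16 log units; within the scatter) and also stays within the scatter, so all three aryl groups on the shared core now read alike in this assay and no difference between them can be claimed. Nothing available bears on why these numbers lie so close together.

Going by these compounds, all three compounds carry a halogen on the phenyl ring, so it remains open whether the flat reading would hold for an amine, a carboxylic acid or a methoxy group at this place. Also open, on these data alone, is the separate contribution of the halogen's place, since in the steps from compound 1 the halogen and its place change together, and a 4-chlorophenyl or 4-iodophenyl group would be needed to pull those two apart.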